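Replacing 4-bromophenyl by 2-fluorophenyl on a shared core

A few compounds are considered here, and "the series" means these few. Any claim that something is new, unique, unknown or untested is made for them only; others in the source may bear on it.

Measured compounds:
compound 1, `c1ccc(-c2cn3ccnc3c(-c3ccc4ncn(C5CCCCC5)c4c3)n2)cc1`, gives 7.87%
compound 2, `COc1ccc(-c2cn3ccnc3c(-c3ccc4ncn(C5CCCCC5)c4c3)n2)cc1`, gives 58.8%
compound 3, `Brc1ccc(-c2cn3ccnc3c(-c3ccc4ncn(C5CCCCC5)c4c3)n2)cc1`, gives 8.95%

In a functional assay on OVCAR-5 cells (Homo sapiens) for inhibition, read by sulforhodamine B assay, with a stated time of 48 h, tested at 10 uM (on this read-out higher numbers stand for more inhibition at the one concentration tested (going by the name of the read-out) and lower numbers for less inhibition), compound 3 sits close to compound 1, the step of a number 1.1 percentage points higher from compound 1 to compound 3 (within the scatter) lying within the scatter, while the step of a number 49.9 percentage points lower from compound 2 to compound 3 (beyond the scatter) leaves it far beneath compound 2. Compound 4, `Fc1ccccc1-c1cn2ccnc2c(-c2ccc3ncn(C4CCCCC4)c3c2)n1`, differs from compound 3 by 2-fluorophenyl in place of 4-bromophenyl on an aromatic carbon. Among the compounds with values here, the steps that bear on this are a number 1.1 percentage points higher from compound 1 to compound 3 (within the scatter), a small one, and a number 49.9 percentage points lower from compound 2 to compound 3 (beyond the scatter), a large one; neither covers a fluorine nor this position, so the change is judged from the halogen step alone. The expected step is a number 3.1 percentage points higher from compound 3 to compound 4 (within the scatter), no change beyond the scatter. Compound 4 is therefore estimated at 12%, ranging from 0% to 40%.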

Compound 4, a percentage reported as inhibition, at one concentration (the size of the read-out at that concentration, not a potency): 6.64%
Estimate against measurement, compound 4: 5.4 percentage points above; the range from low to high includes it.
By their numbers in this assay, from the lowest: compounds 4, 1 and 3 (each within the scatter of the next); then compound 2.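

In this assay, 2-fluorophenyl joins 4-bromophenyl at the level of the unsubstituted phenyl, with a number 1.2 percentage points lower from compound 1 to compound 4 (within the scatter) and a number 2.3 percentage points lower from compound 3 to compound 4 (within the scatter), so exchanging one halogen and its ring place for the other leaves the read-out unchanged. The gap to the 4-methoxyphenyl compound persists, at a number 52.2 percentage points lower from compound 2 to compound 4 (beyond the scatter), and compound 2 remains the only one of the four that stands apart. No evidence is available to explain this. Still open, as far as these compounds go, is whether 2-methoxyphenyl would match compound 2, and whether 4-hydroxyphenyl or 4-aminophenyl would do the same.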